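The source may hold more compounds than are shown below. What is called first, only, known or untested is meant among the compounds shown, and "the series" means these compounds.

Measured in an ADME assay on A549 cells (Homo sapiens) for cytotoxicity, read by resazurin assay, with a stated time of 48 h; a lower number here means that less compound is tolerated, a higher number that more compound is tolerated:
- compound 1 `O=C(Nc1ccc(NCC2CC2)cc1Cl)c1cc(Cl)ccc1O` gives 14400 nM
- compound 2 `CC1(Nc2ccc(NC(=O)c3cc(Cl)ccc3O)c(Cl)c2)CCCC1` gives 157000 nM
- compound 3 `CN(C)c1ccc(NC(=O)c2cc(Cl)ccc2O)c(Cl)c1` gives 85100 nM

Compound 3 cannot be told apart from its nearest neighbour, with a 1.8-fold lower number from compound 2 to compound 3 (0.27 log units; within the scatter). The gap to the lowest number of the set is clear, with a 5.9-fold higher number from compound 1 to compound 3 (0.77 log units; beyond the scatter).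

The next structure is compound 4 `O=C(Nc1ccc(NCc2ccc(Cl)cc2)cc1Cl)c1cc(Cl)ccc1O`, which carries (4-chlorobenzyl)amino in place of dimethylamino on an aromatic carbon.

The most relevant measured step is the one linking dimethylamino to (cyclopropylmethyl)amino, a 5.9-fold higher number from compound 1 to compound 3 (0.77 log units; beyond the scatter). Read backwards, it suggests a lower number once a methylene-linked ring group stands on the nitrogen. The evidence is not uniform, however. Compound 2 goes against any simple rule that a larger nitrogen group lowers the number, with an 11-fold higher number from compound 1 to compound 2 (1.04 log units; beyond the scatter). Among the measured compounds shown here, no measured compound carries a benzyl group, so the range has to stay wide.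

A modest to large step downward is therefore expected in this assay, rather than none. The expected step is a 6.1-fold lower number from compound 3 to compound 4 (0.78 log units; beyond the scatter). For compound 4 the estimate is 14000 nM, with an expected range from 3500 nM to 55000 nM.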

Compound 4, half-maximal cytotoxic concentration: 59700 nM
Compound 4: middle estimate off by 4.3-fold (0.63 log units), on the low side, outside the stated range (above it).
By their numbers in this assay, from the lowest: compound 1; then compounds 4, 3 and 2 (each within the scatter of the next, the first and the last beyond it).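

In this assay, replacing dimethylamino with (4-chlorobenzyl)amino on this aromatic carbon adds an aromatic ring and a hydrogen-bond donor, yet the two compounds cannot be told apart, with a 1.4-fold lower number from compound 3 to compound 4 (0.15 log units; within the scatter). The methylene-linked nitrogen substituent alone therefore does not bring the low number of compound 1, since 4-chlorophenyl in place of cyclopropyl on that saturated chain carbon gives a 4.1-fold higher number from compound 1 to compound 4 (0.62 log units; beyond the scatter), and compound 1 remains the lowest of the four in this assay. The bulky substituents also differ from each other, with 4-chlorobenzyl in place of 1-methylcyclopentyl on the nitrogen giving a 2.6-fold lower number from compound 2 to compound 4 (0.42 log units; beyond the scatter), while no measurement available here explains these differences.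

Open, going by these compounds, is whether the low number of compound 1 is specific to cyclopropylmethyl or would also appear with cyclobutylmethyl or a straight propyl chain on the same nitrogen. Also open, on these data alone, is what the chlorine contributes to the (4-chlorobenzyl)amino group, which an unsubstituted benzyl group or a 4-methoxybenzyl group at this position would help to separate from the contribution of the ring itself.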